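This account rests on a few compounds, and the source may have more. Where it says the series, first, only, none or still open, it means among the compounds named here.

Measured so far in an ADME assay on cells (Hepatocyte, Mus musculus) for metabolic stability, using equilibrium dialysis; on this read-out higher numbers stand for fast clearance and lower numbers for slow clearance:
compound 1, `CC(=O)N[C@@H]1CCC[C@H](C(=O)Nc2cc(-c3cnn4c3CCCC4)c(Cl)cn2)C1`, gives 27 uL/min
compound 2, `CC(=O)N[C@@H]1CCC[C@H](C(=O)Nc2cc(-c3cnn4c3CC(C)(C)C4)c(F)cn2)C1`, gives 75 uL/min

Among the compounds with values here, compound 2 stands highest of the two numbers; compound 1 sits lower by a gap beyond the scatter, but the two differ in more than one place, so no single step is defined between them.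

Compound 3, `CC(=O)N[C@@H]1CCC[C@H](C(=O)Nc2cc(-c3cnn4c3CC(C)(C)C4)c(Cl)cn2)C1`, is not yet measured in this assay. It differs from compound 2 by chloro in place of fluoro on an aromatic carbon. Within the data shown here, no measured pair isolates this exchange; compound 1 also carries chloro and lies lower, yet it differs from compound 2 elsewhere too. The step from compound 2 to compound 3 is expected to be small, a 1.4-fold lower number from compound 2 to compound 3 (0.13 log units; within the scatter), within the scatter and if anything downward. Compound 3 is estimated at 55 uL/min, range 25 uL/min to 120 uL/min.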

Compound 3, intrinsic clearance in a liver preparation (reported as CLH), per the amount of preparation that the assay uses: 98 uL/min
Beside the measured number, compound 3's estimate is 1.8-fold (0.25 log units) below it, within the range that was stated.
By their numbers in this assay, from the lowest: compound 1; then compounds 2 and 3 (each within the scatter of the next).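

In this assay, chloro in place of fluoro on this aromatic carbon, ortho to a large group, stays within the scatter (a 1.3-fold higher number from compound 2 to compound 3 (0.12 log units; within the scatter)). With chloro held constant, the group exchange on the other aromatic carbon can now be read alone, a five-membered non-aromatic ring in place of a six-membered one (a 3.6-fold higher number from compound 1 to compound 3 (0.56 log units; beyond the scatter)). Nothing available explains either step.

Going by these compounds, whether fluoro and chloro also match when the six-membered ring is present stays open. So does the effect of a nitrile or methyl group at the halogen position.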